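The compounds below may be only part of what the source reports. "The series", "measured", "known", "first", "only" and "open" are said of these compounds alone.

Measured so far:
compound 1, `Cc1cccc(Cn2c(CN3CCN(C(=O)C4CCCCC4)CC3)nc3ccccc32)c1`: 31.9%
compound 2, `O=C(C1CC1)N1CCN(Cc2nc3ccccc3n2Cc2ccc(C(F)(F)F)cc2)CC1`: 37%

In an assay on isolated protein for inhibition of aldehyde dehydrogenase 1A1 (Homo sapiens), read by spectrophotometry, tested at 10 uM (a lower number here means less inhibition, a higher number more inhibition at the concentration tested (going by the name of the read-out)), compound 1 gives 31.9% and compound 2 gives 37%. The two numbers lie within the usual scatter of each other, so nothing separates compound 1 from compound 2 on these data. Compound 3, `Cc1cccc(Cn2c(CN3CCN(C(=O)c4ccncc4)CC3)nc3ccccc32)c1`, has not yet been measured. Relative to compound 1 it carries a single change: pyridin-4-yl in place of cyclohexyl on a carbonyl carbon. Among the measured compounds shown here, the two measured compounds differ from each other in more than one place, so no step between them tells what such a change does in this assay. With nothing to go on beyond the value of compound 1, the step expected from compound 1 to compound 3 is set small, a number 2.9 percentage points lower from compound 1 to compound 3 (within the scatter), in no firm direction and not beyond the scatter. Compound 3 is accordingly estimated at 29%, with a range from 10% to 50%.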

Compound 3, a percentage reported as inhibition, at one concentration (the size of the read-out at that concentration, not a potency): 20.6%
Beside the measured number, compound 3's estimate is 8.4 percentage points above it, within the range that was stated.
By their numbers in this assay, from the lowest: compound 3; then compounds 1 and 2 (each within the scatter of the next).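

In this assay, among the compounds shown here, the first single-place change, pyridin-4-yl in place of cyclohexyl on a carbonyl carbon, reads as a number 11.3 percentage points lower from compound 1 to compound 3 (beyond the scatter) and is modest in size. This position is therefore not indifferent to the group it carries, even between two six-membered rings with the same count of heavy atoms, which the earlier pair could not show. No measurement on hand says what about this change accounts for the step.

The compounds shown do not tell whether the step goes with the ring nitrogen of pyridin-4-yl or with the aromatic ring itself, and a phenyl group on the same carbonyl carbon would separate the two. Also open, as far as these compounds go, is how a pyridin-3-yl group, or an open alkyl chain, would read at this position.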